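The compounds below may be only part of what the source reports. "The series", "measured", "known", "first", "only" and "open" are said of these compounds alone.

Compound 1 `Cc1[nH]c2ccccc2c(=O)c1Cc1ccccc1` is the parent of this small set. In a physicochemical assay for solubility, read by HPLC, at pH 7.4 (on this read-out lower numbers stand for lower solubility and higher numbers for higher solubility), compound 1 gives 10000 nM, the highest of the numbers shown, with compound 3 `Cc1[nH]c2c(Cl)cccc2c(=O)c1Cc1ccccc1` nearest at 5000 nM. Compound 2 `Cc1[nH]c2ccc(Cl)cc2c(=O)c1Cc1ccccc1` sits at a limit of the assay, < 2000 nM. Compound 4 `Cc1[nH]c2cc(Cl)ccc2c(=O)c1Cc1ccccc1` differs from compound 1 by chloro in place of hydrogen on an aromatic carbon. Two measured steps make the same kind of change at other places on the same ring: an at least 5.0-fold lower number from compound 1 to compound 2 (0.69 log units; beyond the scatter) and a 2.0-fold lower number from compound 1 to compound 3 (0.30 log units; within the scatter). Both point the same way, one beyond the scatter and one within it, so a lower number is expected for compound 4, probably of modest size, and the limit of < 2000 nM in this assay, at which 1 of the 3 values shown sits, is a reminder that a limit rather than a number is possible. Compound 4 is therefore estimated at 3500 nM, within 1500 nM to 8000 nM. The expected change is a 2.9-fold lower number from compound 1 to compound 4 (0.46 log units; beyond the scatter).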

Compound 4, solubility: < 2000 nM
Compound 4 ended at the assay's limit; the forecaster's own chance of this, stated with the estimate: 30%; middle value at least 1.7-fold (0.24 log units) away from the limit.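

In this assay, chloro in place of hydrogen at this place, meta to a fused ring and para to a fused ring, gives an at least 5.0-fold lower number from compound 1 to compound 4 (0.69 log units; beyond the scatter). On these data alone, this shows the change reaching beyond the scatter here, although compound 4 gives a limit and not a number, so the full size of the step stays unknown. The limit now holds a larger share of the set: the limit of < 2000 nM in this assay, at which 2 of the 4 values shown sit.

The compounds shown leave open the actual number for compound 4. They also leave open how an amine or a carboxylic acid would read at this place.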